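The source may hold more compounds than are shown below. What is called first, only, known or untested is meant among the compounds shown, and "the series" means these compounds.

All the compounds here share the core of compound 1 `CCOC(=O)/C(=C/c1ccccc1)CN1C(=O)[C@@H](OC)[C@H]1c1ccc(Cl)cc1`, and they were tested in an ADME assay on cells (Epithelial cell, Homo sapiens) for antiproliferative activity, read by MTT assay, with a stated time of 48 h; a lower number here means a stronger inhibitor, a higher number a weaker inhibitor. In this assay compound 1 is reported only as ("not toxic" (no number reported)) with no number attached. Compound 2 `CCOC(=O)/C(=C/c1ccccc1)CN1C(=O)[C@@H](OC)[C@H]1c1cccc([N+](=O)[O-])c1` stands in the same place, reported as ("not toxic" (no number reported)), so it has no number to serve as a starting point. Among the measured compounds shown here, the only number in this small set belongs to compound 3 `COC(=O)/C(=C/c1ccccc1)CN1C(=O)[C@@H](OC)[C@H]1c1ccc(Cl)cc1Cl` (70000 nM).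

Compound 4 `CCOC(=O)/C(=C/c1ccccc1)CN1C(=O)[C@@H](OC)[C@H]1c1ccccc1Br` has not yet been measured. Its structural change is 2-bromophenyl in place of 3-nitrophenyl on a saturated ring carbon and puts 2-bromophenyl in place of 3-nitrophenyl on a saturated ring carbon. For the measured compounds named here, no measured step in this set shows what such a swap does, so the size of the step can only be guessed. The expectation is no clear move in either direction, with the result staying weak, close to compound 3 (70000 nM) or again without a number. In this assay the estimated value for compound 4 is 60000 nM with an expected range (20000 nM to 180000 nM).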

Compound 4, half-maximal inhibitory concentration: 66600 nM
Beside the measured number, compound 4's estimate is 1.1-fold (0.05 log units) below it; low and high end bracket the measured number.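

Among the compounds shown here, compound 2 has no number, so compound 4 at 66600 nM gives no step between the two that can be read. No other measurement here helps to explain this result. These compounds leave open how far 2-bromophenyl in place of 3-nitrophenyl shifts antiproliferative activity on its own.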